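Series notes: thioether ester amides in a cytotoxicity screen

The source may report more compounds than this note shows. Statements on the series, on what has been measured and on what is new or still open speak of the compounds shown alone.

In an ADME assay on CEM-SS cells (Homo sapiens) for cytotoxicity, read by XTT assay, with a stated time of 6 days (on this read-out lower numbers stand for higher toxicity in this test and higher numbers for lower toxicity in this test), compound 1 `CCCC(=O)OCSc1ccccc1C(=O)NCCCCCC(N)=O` gives 16.3 uM. Compound 2 `CCCC(=O)OCSc1ccccc1C(=O)N[C@H]1CCC[C@@H]1C(N)=O` has repeated entries, 31.2 uM; 43.3 uM (2 entries), and compound 3 `CCCC(=O)OCSc1ccccc1C(=O)N[C@H]1CCC[C@H]1C(N)=O` likewise, 89.9 uM; 84.8 uM (2 entries); compounds 2 and 3 differ only in configuration as drawn (the fact that compounds 2 and 3 differ only in the configuration as drawn). Among the numbers shown, compound 1 carries the lowest single value, while compounds 2 and 3 each rest on two entries.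

Compound 4 `CCCC(=O)OCSc1ccccc1C(=O)NCC(=O)NCCN(C)C` is not yet measured in this assay. It differs from compound 1 as follows: (2-(dimethylamino)ethyl)carbamoyl in place of 4-carbamoylbutyl on a saturated chain carbon bound to an amide-type nitrogen. Among the measured compounds shown here, no measured step of this kind exists in the set, so the step from compound 1 to compound 4 is expected to stay within the usual scatter, a 1.2-fold higher number from compound 1 to compound 4 (0.09 log units; within the scatter). Compound 4 is therefore estimated at 20 uM, with a range from 7 uM to 60 uM.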

Compound 4, half-maximal toxic concentration: 76.9 uM
The estimate for compound 4 lay 3.8-fold (0.58 log units) below the measured number; the whole stated range lies below it.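

In this assay, among the compounds shown here, the change to (2-(dimethylamino)ethyl)carbamoyl in place of 4-carbamoylbutyl, on a saturated chain carbon bound to an amide-type nitrogen, gives a 4.7-fold higher number from compound 1 to compound 4 (0.67 log units; beyond the scatter) and is the first readable step. This place therefore responds to the group it carries, here towards lower toxicity in this test. Nothing at hand bears on the cause of this step.

Still open, going by these compounds, is whether the dimethylamino group alone carries the step, and how a carboxylic acid or a longer chain would read in this assay at this place.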